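From Chloro to Nitro on Compound 3

The source may hold more compounds than are shown below. What is called first, only, known or untested is meant among the compounds shown, and "the series" means these compounds.

Measured in a functional assay on MCF7 cells (Homo sapiens) for antiproliferative activity, read by MTT assay, with a stated time of 48 h; a higher number here means a weaker inhibitor, a lower number a stronger inhibitor:
- compound 1 `O=[N+]([O-])c1ccc(-c2nn(-c3ccccc3)cc2C(Nc2nc3ccccc3s2)c2c(O)ccc3ccccc23)cc1` gives 14700 nM
- compound 2 `O=[N+]([O-])c1cccc(-c2nn(-c3ccccc3)cc2C(Nc2nc3ccc(Cl)cc3s2)c2c(O)ccc3ccccc23)c1` gives 19700 nM
- compound 3 `Oc1ccc2ccccc2c1C(Nc1nc2ccc(Cl)cc2s1)c1cn(-c2ccccc2)nc1-c1ccc(Cl)cc1` gives 27500 nM

Compound 3 lies within the usual scatter of both compound 1 and compound 2, so repeat measurements alone could account for the gaps between it and them. The next compound, compound 4 `O=[N+]([O-])c1ccc(-c2nn(-c3ccccc3)cc2C(Nc2nc3ccc(Cl)cc3s2)c2c(O)ccc3ccccc23)cc1`, keeps everything in compound 3 except one group: nitro in place of chloro on an aromatic carbon. Its 4-chlorophenyl thus becomes a 4-nitrophenyl.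

For the measured compounds named here, only one measured step bears directly on this swap: a 1.4-fold higher number from compound 2 to compound 3 (0.14 log units; within the scatter). It also links a nitro-bearing group, placed differently, to the 4-chlorophenyl, and it stays within the scatter. Compound 1 also carries a 4-nitrophenyl and gives 14700 nM, a value that likewise sits close to the others. On this small evidence, no step beyond the scatter is expected in this assay. The estimate means an expected 1.4-fold lower number from compound 3 to compound 4 (0.16 log units; within the scatter). Compound 4 is estimated at 19000 nM, with an expected range from 10000 nM to 36000 nM.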

Compound 4, half-maximal inhibitory concentration: 38600 nM
For compound 4 the middle estimate is 2.0-fold (0.31 log units) below the measured one, and the stated range ends below it.
By their numbers in this assay, from the lowest: compounds 1, 2, 3 and 4 (each within the scatter of the next, the first and the last beyond it).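

In this assay, nitro in place of chloro, on an aromatic carbon para to a large group, gives a 1.4-fold higher number from compound 3 to compound 4 (0.15 log units; within the scatter), so the assay does not separate these two groups here, although they differ in heavy atoms and hydrogen-bond acceptors. Moving the nitro group, with 4-nitrophenyl in place of 3-nitrophenyl, gives a 2.0-fold higher number from compound 2 to compound 4 (0.29 log units; within the scatter), so the assay does not separate these two arrangements either, and neither change to this aryl group moves the number beyond the usual scatter. For the compounds shown here, the only step here beyond the scatter lies elsewhere in the molecule: chloro in place of hydrogen, with the 4-nitrophenyl kept, gives a 2.6-fold higher number from compound 1 to compound 4 (0.42 log units; beyond the scatter), a modest rise that points to a weaker inhibitor and rests on this single pair.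

Nothing available explains any of these steps, whether through a measured property of the groups or otherwise. Going by these compounds, it remains open whether a quite different group at the para carbon of this phenyl ring, such as an amine or a carboxylic acid, would shift the number beyond the scatter, and whether the chloro step would recur with another aryl group in place of the 4-nitrophenyl.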